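Chloro in Place of Hydrogen: Compound 3 to Compound 4

The source may hold more compounds than are shown below. What is called first, only, known or untested is meant among the compounds shown, and "the series" means these compounds.

Within the data shown here, compound 3 `CCCCCN(CCCCC)C(=O)[C@H]1CCN(C(=O)N(c2ccccc2)c2ccccc2)[C@H](C(=O)NCCNCC(N)=O)C1` holds the second highest of the three numbers so far in an assay on CHO cells for binding affinity to Substance-P receptor (Homo sapiens) (on this read-out lower numbers stand for stronger inhibition and higher numbers for weaker inhibition), where compound 3 gives 13 nM. Its nearest neighbour is compound 1 `CCCCCN(CCCCC)C(=O)[C@H]1CCN(C(=O)N(c2ccccc2)c2cccc(Cl)c2)[C@H](C(=O)O)C1`, which in this assay gives 20 nM; that number lies within the scatter of compound 3, so no order between the two is claimed. Furthest away is compound 2 `CCCCCN(CCCCC)C(=O)[C@H]1CCN(C(=O)N(c2ccccc2)c2cccc(Cl)c2)[C@H](C(=O)NCCN(CC(N)=O)C(=O)OCc2ccccc2)C1`, which in this assay gives 1.8 nM, a lower number beyond the scatter. Among the measured compounds shown here, compound 1 and compound 2 each differ from compound 3 in more than one place, so no single-place step between measured compounds is at hand; their numbers show only that both compounds carrying the 3-chlorophenyl group sit at or below compound 3.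

Compound 4 `CCCCCN(CCCCC)C(=O)[C@H]1CCN(C(=O)N(c2ccccc2)c2cccc(Cl)c2)[C@H](C(=O)NCCNCC(N)=O)C1` differs from compound 3 in one place: chloro in place of hydrogen on an aromatic carbon, meta to a large group. For the measured compounds named here, no measured step of this kind exists. The expectation of a move toward lower numbers rests on compound 2, because its value 1.8 nM is the lowest shown while it carries that same chloro. For compound 4 a modest step is expected, a 2.2-fold lower number from compound 3 to compound 4 (0.34 log units; beyond the scatter), possibly not beyond the scatter. The estimate for compound 4 is 6 nM, with a range from 2.5 nM to 15 nM.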

Compound 4, half-maximal inhibitory concentration: 3.5 nM
Compound 4: the middle estimate sits 1.7-fold (0.23 log units) above what was measured, and the stated range covers the measured number.
By their numbers in this assay, from the lowest: compounds 2 and 4 (each within the scatter of the next); then compounds 3 and 1 (each within the scatter of the next).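

Among these compounds, compound 3 and compound 4 give the first single-place reading of chloro in place of hydrogen on this aromatic carbon: in this assay there is a 3.7-fold lower number from compound 3 to compound 4 (0.57 log units; beyond the scatter), a step beyond the scatter that the earlier compounds could only hint at. With the 3-chlorophenyl group held fixed, the benzyloxycarbonyl on the amine nitrogen can be exchanged for hydrogen with no readable change, since a 1.9-fold higher number from compound 2 to compound 4 (0.29 log units; within the scatter) stays within the scatter, so the low number of compound 2 does not depend on that group on this evidence. Among the compounds shown here, the amide side chain can also be read on its own for the first time: a 5.7-fold lower number from compound 1 to compound 4 (0.76 log units; beyond the scatter), for (2-((carbamoylmethyl)amino)ethyl)amino in place of hydroxy on the carbonyl carbon, lies beyond the scatter.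

Still open, on these data alone, is whether fluoro, bromo, methyl or methoxy at the same place would match chloro, and whether phenyl to 3-chlorophenyl gives a similar step in a series carrying the carboxylic acid or the benzyloxycarbonyl group. No supporting data are at hand to account for the size of any of these steps.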